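Cyclopropyl Replaces Chlorophenyl on the Sulfur Arm

A few compounds are considered here, and "the series" means these few. Any claim that something is new, unique, unknown or untested is made for them only; others in the source may bear on it.

Compound 1 `Cc1cc(Nc2cc(-c3ccccc3)[nH]n2)n2nc(SCc3ccc(Cl)cc3)nc2n1` is the starting point of this account. In a functional assay on PC-9 cells (Homo sapiens) for inhibition, read by MTT assay, with a stated time of 72 h (on this read-out lower numbers stand for stronger inhibition and higher numbers for weaker inhibition), compound 1 gives 6710 nM, the upper of the two numbers measured, though its nearest neighbour, compound 2 `Cc1cc(Nc2ccn(Cc3nc(C)c4ccccc4n3)n2)n2nc(SCc3ccc(Br)cc3)nc2n1` with 5450 nM in this assay, lies within the scatter of it, so the two cannot be ordered. Compound 3 `COc1ccc(Cn2ccc(Nc3cc(C)nc4nc(SCc5ccc(Br)cc5)nn34)n2)cc1` reaches only the assay limit, > 50000 nM, in this assay. Within the data shown here, the single measured step, an at least 9.1-fold higher number from compound 2 to compound 3 (0.96 log units; beyond the scatter), concerns the group on the saturated chain carbon bound to an aromatic nitrogen, and one of its two values is a limit (the limit of > 50000 nM in this assay, at which 1 of the 3 values shown sits); it says nothing about the sulfur-bound chain.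

Compound 4 `Cc1cc(Nc2cc(-c3ccccc3)[nH]n2)n2nc(SCC3CC3)nc2n1` differs from compound 1 at that chain: cyclopropyl in place of 4-chlorophenyl on a saturated chain carbon bound to a sulfur. Among the measured compounds shown here, no measured step touches this place, so the expectation rests on the change itself. Compound 4 is expected to give 15000 nM in this assay, between 4000 nM and 50000 nM, an estimated step of a 2.2-fold higher number from compound 1 to compound 4 (0.35 log units; beyond the scatter) toward weaker inhibition.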

Compound 4, half-maximal inhibitory concentration: > 50000 nM
Compound 4 was reported as a limit; the forecaster's own chance of this, stated with the estimate: 25%; middle value at least 3.3-fold (0.52 log units) from the limit.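

The earlier step concerned only the group on the nitrogen-bound chain carbon, whereas this pair shows that the sulfur arm also matters in this assay: with the rest of compound 1 unchanged, cyclopropyl in place of 4-chlorophenyl gives an at least 7.4-fold higher number from compound 1 to compound 4 (0.87 log units; beyond the scatter). Within this pair, only the 4-chlorophenyl group gives a value short of the limit, so the change from 7 heavy atoms and an aromatic ring to 3 heavy atoms and a three-membered ring is not tolerated at this place in this assay. The value of compound 4 is a limit, so the step has a lower bound but no full size: the limit of > 50000 nM in this assay, at which 2 of the 4 values shown sit.

The compounds shown leave open whether the chlorine or the aromatic ring itself accounts for the difference, a question that a plain benzyl group on the sulfur would address. They also leave open how a longer chain such as n-butyl, or an amine on the benzyl ring, would read at this place.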